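The source may report more compounds than this note shows. Statements on the series, on what has been measured and on what is new or still open speak of the compounds shown alone.

Of the compounds shown here, two have so far been measured in a functional assay on MCF7 cells (Homo sapiens) for inhibition, read by sulforhodamine B assay, with a stated time of 72 h; on this read-out lower numbers stand for stronger inhibition and higher numbers for weaker inhibition. Compound 1, `COc1cc(C(=O)/C=C/c2cn(-c3ccccc3)nc2-c2ccsc2)cc(OC)c1OC`, gives 4900 nM in this assay. Compound 2, `O=C(/C=C/c1cn(-c2ccccc2)nc1-c1cccnc1)c1cc[nH]c1`, gives 6900 nM in this assay. These two numbers lie within the usual scatter of one another, so the measurements do not separate compound 2 from compound 1; its number is one of two that sit close together. Among the measured compounds shown here, no step between measured compounds that differ in a single place is available, so nothing measured here tells how an exchange at the carbonyl carbon shifts the read-out.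

Compound 3, `COc1ccc(OC)c(C(=O)/C=C/c2cn(-c3ccccc3)nc2-c2cccnc2)c1`, is not yet measured. It differs from compound 2 in one place: 2,5-dimethoxyphenyl in place of 1H-pyrrol-3-yl on a carbonyl carbon. Because compound 1 gives 4900 nM, a number close to that of compound 2, the exchange is expected to move the read-out little, if at all, beyond the scatter. The step from compound 2 to compound 3 is therefore expected to be a 1.5-fold lower number from compound 2 to compound 3 (0.19 log units; within the scatter). Compound 3 is estimated at 4500 nM in this assay, with a likely range from 1500 nM to 13000 nM.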

Compound 3, half-maximal inhibitory concentration: 1500 nM
The estimate for compound 3 lay 3.0-fold (0.48 log units) above the measured number, within the range that was stated.
By their numbers in this assay, from the lowest: compound 3; then compounds 1 and 2 (each within the scatter of the next).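

The carbonyl carbon is a position that responds to change: in this assay, exchanging the 1H-pyrrol-3-yl for 2,5-dimethoxyphenyl gives a 4.6-fold lower number from compound 2 to compound 3 (0.66 log units; beyond the scatter), a modest step but one that exceeds the usual variation between repeat measurements. Among the compounds shown here, this is the first exchange at a single place, so it gives the first direct reading of how this position affects the result, and it favours the larger group of 10 heavy atoms, which has 2 hydrogen-bond acceptors and no donor, over the group of 5 heavy atoms with 1 donor. Several features change together in this one exchange, and no measurement available here explains why the number falls or assigns the step to any one of those features.

Going by these compounds, it remains open whether the six-membered carbon ring alone accounts for the step or whether the two methoxy groups are also needed, a question that a plain phenyl at the same carbon could help to answer. On these data alone, how this position would respond to a quite different group, such as an amine or a carboxylic acid, also remains unknown.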